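A few compounds are considered here, and "the series" means these few. Any claim that something is new, unique, unknown or untested is made for them only; others in the source may bear on it.

In a toxicity assay on HT-29 cells (Homo sapiens) for cytotoxicity (on this read-out lower numbers stand for higher toxicity in this test and higher numbers for lower toxicity in this test), the compounds here share one core and differ in what sits on an aromatic nitrogen. Compound 1 `CN1C(=S)[C@@H](NC(=O)c2n[nH]c(Cc3ccccc3)n2)COc2ccccc21`, with hydrogen there, gives only a limit, > 50000 nM. Compound 2 `CCCCCn1nc(C(=O)N[C@H]2COc3ccccc3N(C)C2=S)nc1Cc1ccccc1`, with pentyl, also gives only a limit, > 100000 nM. Compound 3 `CN1C(=S)[C@@H](NC(=O)c2nc(Cc3ccccc3)n(CCCF)n2)COc2ccccc21`, with 3-fluoropropyl, likewise gives only a limit, > 100000 nM, and so stands at the limit of > 100000 nM in this assay, at which 2 of the 3 values shown sit.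

Compound 4 `CN1C(=S)[C@@H](NC(=O)c2nc(Cc3ccccc3)n(CCCC#N)n2)COc2ccccc21` changes that chain, as counted in cyano in place of fluoro on a saturated chain carbon, three bonds along the chain from an aromatic nitrogen. The nearest measured change is a step that the two limits leave unreadable from compound 2 to compound 3, made at the same chain carbon. The other two changes are a step that the two limits leave unreadable from compound 1 to compound 2 and a step that the two limits leave unreadable from compound 1 to compound 3. None of these gives a size to carry over, and no exact number exists in this assay for any measured compound. No change beyond the usual scatter is therefore expected, and the expected step is a number no higher from compound 3 to compound 4 (the limit leaves the size open). Compound 4 is estimated at 100000 nM, with an expected range from 40000 nM to 200000 nM.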

Compound 4, half-maximal cytotoxic concentration: > 100000 nM
Compound 4: a limit, no number; the forecaster's own chance of this, stated with the estimate: 85%; the middle value sits exactly at the limit.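

For the compounds shown here, compound 4, like compound 1, compound 2 and compound 3, gives only a limit, and no step from any of them to compound 4 can be read. Left open is the exact value of each of the four compounds, and whether the group on the aromatic nitrogen changes it at all.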